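A few compounds are considered here, and "the series" means these few. Any claim that something is new, unique, unknown or untested is made for them only; others in the source may bear on it.

Compound 3 `CC1=C(N2CC2)C(=O)C(CCC(=O)N(C)C)=C(N2CC2)C1=O` gives 4.84 in a functional assay on L1210 cells (Mus musculus), with a stated time of 1 days (on this read-out higher numbers stand for higher potency (the scale is a negative logarithm) and lower numbers for lower potency), the lowest of the three numbers in hand; compound 2 `COCCC1=C(N2CC2)C(=O)C(C)=C(N2CC2)C1=O` gives 5.12 and compound 1 `CC1=C(N2CC2)C(=O)C(CCCOC(N)=O)=C(N2CC2)C1=O` gives 5.48. The measured steps each alter one group on the chain carbon: a number 0.36 log units lower from compound 1 to compound 2 (beyond the scatter), a number 0.64 log units lower from compound 1 to compound 3 (beyond the scatter), and a number 0.28 log units lower from compound 2 to compound 3 (within the scatter). Compound 4 `COC(CO)C1=C(N2CC2)C(=O)C(C)=C(N2CC2)C1=O` differs from compound 3 on a double-bonded ring carbon, (2-hydroxy-1-methoxyethyl in place of 2-(dimethylcarbamoyl)ethyl on a double-bonded ring carbon). Within the data shown here, no measured step swaps the whole chain, so none bears directly on this change; the nearest guide is the step between compound 2 and compound 3, which stays within the scatter. Compound 4 is therefore expected to sit near compound 2. The expected step is a number 0.31 log units higher from compound 3 to compound 4 (beyond the scatter), small enough that it may lie within the scatter. The estimate for compound 4 is 5.15, with a range from 4.65 to 5.65.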

Compound 4, logarithm of the reciprocal of the active concentration, log(1/C): 5.27
Compound 4: middle estimate off by 0.12 log units, on the low side; the measured number falls inside the stated range.
By their numbers in this assay, from the lowest: compounds 3, 2, 4 and 1 (each within the scatter of the next, the first and the last beyond it).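

In this assay, 2-hydroxy-1-methoxyethyl on this double-bonded ring carbon gives a number 0.43 log units higher from compound 3 to compound 4 (beyond the scatter) and so separates from the 2-(dimethylcarbamoyl)ethyl group. The other two readings are a number 0.15 log units higher from compound 2 to compound 4 (within the scatter) and a number 0.21 log units lower from compound 1 to compound 4 (within the scatter), so compound 4 cannot be ranked against either, although those two neighbours stand apart from each other. Nothing available accounts for these steps. Going by these compounds, the separate shares of the hydroxy and methoxy parts of this group remain open. So does the effect of an amine or a carboxylic acid on this ring carbon.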